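A few compounds are considered here, and "the series" means these few. Any claim that something is new, unique, unknown or untested is made for them only; others in the source may bear on it.

Three compounds built on a shared core were tested in a functional assay on ECa-109 cells (Homo sapiens) for antiproliferative activity, read by MTT assay, with a stated time of 48 h; a higher number here means a weaker inhibitor, a lower number a stronger inhibitor. Compound 1 `Cn1cc(C2=C(c3n[nH]c4ncccc34)C(=O)N(c3cccc4ccccc34)C2=O)c2ccccc21` gives only a limit of the assay, > 100000 nM. Compound 2 `Cn1cc(C2=C(c3nn(CCCn4cccc4)c4ncccc34)C(=O)N(c3ccccc3)C2=O)c2ccccc21` likewise reaches only the limit, > 100000 nM. Compound 3 `Cn1cc(C2=C(c3nn(CCCO)c4ncccc34)C(=O)NC2=O)c2ccccc21` also stops at the limit, > 100000 nM. Among the measured compounds shown here, compound 2 therefore stands where every value shown stands, at the limit of > 100000 nM in this assay, at which 3 of the 3 values shown sit, and no measured step separates it from the others. Compound 4 `Cn1cc(C2=C(c3nn(CCCN4CCCCC4)c4ncccc34)C(=O)N(c3ccccc3)C2=O)c2ccccc21` has not yet been measured in this assay; it differs from compound 2 in one place: piperidin-1-yl in place of 1H-pyrrol-1-yl on a saturated chain carbon, three bonds along the chain from an aromatic nitrogen. For the measured compounds named here, no measured pair shows what this change does, so the step that is expected is a number no higher from compound 2 to compound 4 (the limit leaves the size open), none beyond the scatter. Compound 4 is thus expected to give about 100000 nM, within 40000 nM to 250000 nM, most likely reported again as a limit.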

Compound 4, half-maximal inhibitory concentration: 12300 nM
Beside the measured number, compound 4's estimate is 8.1-fold (0.91 log units) above it, and the stated range ends above it.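

Replacing 3-(1H-pyrrol-1-yl)propyl with 3-(piperidin-1-yl)propyl gives an at least 8.1-fold lower number from compound 2 to compound 4 (0.91 log units; beyond the scatter) in this assay, which shows that the group at the end of this chain can bring the series off the limit. Compound 4 is the only compound shown with a measured number rather than a limit: the limit of > 100000 nM in this assay, at which 3 of the 4 values shown sit.

The compounds shown leave open whether another amine on this chain, such as morpholin-4-yl or dimethylamino, would give a lower number. They also leave open how a longer chain carrying piperidin-1-yl would behave.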